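The source may report more compounds than this note shows. Statements on the series, on what has been measured and on what is new or still open speak of the compounds shown alone.

Measured in a functional assay on OVCAR-8 cells (Homo sapiens) for inhibition, read by sulforhodamine B assay, with a stated time of 48 h; a higher number here means a weaker inhibitor of growth, a lower number a stronger inhibitor of growth:
compound 1 `CCOC(=O)[C@H](CCC(=O)O)NC(=O)c1ccc(Sc2nc3cc(N)cc(N)c3nc2-c2ccccc2)cc1` gives 12000 nM
compound 2 `COc1cc(CNc2nc3cc(N)cc(N)c3nc2-c2ccccc2)cc(OC)c1OC` gives 6920 nM
compound 3 `COc1ccc(CNc2nc3cc(N)cc(N)c3nc2-c2ccccc2)cc1OC` gives 6760 nM

Compound 3 holds the lowest of the three numbers, but its nearest neighbour compound 2 and the furthest, compound 1, both sit within the scatter of it, so no order among the three can be read. Among the measured compounds shown here, the single measured step of the same kind, a 1.0-fold lower number from compound 2 to compound 3 (0.01 log units; within the scatter), stayed within the scatter.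

Compound 4 `COc1ccc(CNc2nc3cc(N)cc(N)c3nc2-c2ccccc2)cc1` differs from compound 3 in one place: hydrogen in place of methoxy on an aromatic carbon. For the measured compounds named here, the only comparable step, a 1.0-fold lower number from compound 2 to compound 3 (0.01 log units; within the scatter), gives no reason to expect movement, so the estimated step of a 1.0-fold higher number from compound 3 to compound 4 (0.02 log units; within the scatter) is none beyond the scatter. Compound 4 is therefore expected to give 7000 nM in this assay, with a range of 3000 nM to 16000 nM.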

Compound 4, concentration for 50% growth inhibition: 14800 nM
Beside the measured number, compound 4's estimate is 2.1-fold (0.33 log units) below it, within the range that was stated.
By their numbers in this assay, from the lowest: compounds 3, 2, 1 and 4 (each within the scatter of the next, the first and the last beyond it).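

In this assay, hydrogen in place of methoxy, ortho to a methoxy group, gives a 2.2-fold higher number from compound 3 to compound 4 (0.34 log units; beyond the scatter), a modest step beyond the scatter, whereas the same kind of change in a 1.0-fold lower number from compound 2 to compound 3 (0.01 log units; within the scatter) stayed within it. Loss of a methoxy group therefore does not read alike in these two steps, and going from 3,4-dimethoxyphenyl to 4-methoxyphenyl is the one that shows in the numbers. No measurement shown bears on the reason for this step. Still open, as far as these compounds go, is whether a hydroxy group or an amine at this position would keep the number of compound 3.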